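The compounds below may be only part of what the source reports. "The series", "measured", "known", "first", "only" and "open" are said of these compounds alone.

Compound 1 `COc1ccc2[nH]c(-c3cccc(F)c3)cc(=O)c2c1OC` and compound 2 `COc1ccc2[nH]c(-c3ccc(F)cc3)cc(=O)c2c1OC` share one core and differ in a single place: 4-fluorophenyl in place of 3-fluorophenyl on an aromatic carbon. In a functional assay on HL-60 cells (Homo sapiens) for cytotoxicity, read by MTT assay, with a stated time of 48 h (a higher number here means a weaker inhibitor, a lower number a stronger inhibitor), compound 1 gives 1300 nM, and compound 2 gives 2000 nM, which is a step of a 1.5-fold higher number from compound 1 to compound 2 (0.19 log units; within the scatter). Compound 3 `COc1cc2c(=O)cc(-c3cccc(F)c3)[nH]c2cc1O` is built on a second core; the difference between the two cores is not broken down here. In this assay compound 3 gives 900 nM. Compound 4 `COc1cc2c(=O)cc(-c3ccc(F)cc3)[nH]c2cc1O` has not been measured yet and is related to compound 3 by the same change: 4-fluorophenyl in place of 3-fluorophenyl on an aromatic carbon. The step to compound 4 is expected to be of similar size, a 1.5-fold higher number from compound 3 to compound 4 (0.18 log units; within the scatter), because the same change gave a 1.5-fold higher number from compound 1 to compound 2 (0.19 log units; within the scatter). For compound 4 the expected value in this assay is 1350 nM, most likely between 600 nM and 3000 nM.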

Compound 4, half-maximal inhibitory concentration: 38200 nM
The estimate for compound 4 lay 28-fold (1.45 log units) below the measured number; the whole stated range lies below it.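

In this assay, putting 4-fluorophenyl in place of 3-fluorophenyl on the second core gives a 42-fold higher number from compound 3 to compound 4 (1.63 log units; beyond the scatter), so the change did not carry over from one core to the other at the same size: the same change on two cores in this assay, a 1.5-fold higher number (0.19 log units; within the scatter) from compound 1 to compound 2 and a 42-fold higher number (1.63 log units; beyond the scatter) from compound 3 to compound 4, 28-fold (1.44 log units) apart, beyond the scatter of two such steps. For these two pairs, then, the size of the step depends on the core, and a step read on one core was a poor guide to the other. This does not show which feature of the cores makes the difference, and two pairs set no rule for the whole series.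

The compounds shown leave open whether a chlorine on the phenyl ring would behave the same way. They also leave open what an amine in place of the hydroxyl on the core of compound 3 would do.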